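Carbamoyl in Place of Methoxymethoxy: Expected Cell Tolerance

A few compounds are considered here, and "the series" means these few. Any claim that something is new, unique, unknown or untested is made for them only; others in the source may bear on it.

Compound 1 `CCc1ccc2[nH]c(=O)c(CN(Cc3cccc(F)c3)Cc3ccc4ccccc4c3)cc2c1` gives in a toxicity assay on MDCK cells (Canis lupus familiaris) for cytotoxicity, read by crystal violet staining, with a stated time of 48 h (a higher number here means that more compound is tolerated, a lower number that less compound is tolerated), only a limit, > 5000 nM.
Compound 2 `COCOc1ccc(CN(Cc2ccc(C(C)(C)C)cc2)Cc2cc3cc(C)ccc3[nH]c2=O)cc1` gives in this assay 6400 nM.
Compound 3 `CCc1ccc2[nH]c(=O)c(CN(Cc3ccc(OCOC)cc3)Cc3ccc(C(C)(C)C)cc3)cc2c1` gives in this assay only a limit, > 10000 nM.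

Among the compounds with values here, compound 2 is thus the one compound with an actual number; the other two values are limits. Within the data shown here, the one measured step, an at least 1.5-fold higher number from compound 2 to compound 3 (0.19 log units; that floor lies within the scatter), changes a different part of the molecule, so it does not bear on the change to compound 4 `Cc1ccc2[nH]c(=O)c(CN(Cc3ccc(C(N)=O)cc3)Cc3ccc(C(C)(C)C)cc3)cc2c1`, which is carbamoyl in place of methoxymethoxy on an aromatic carbon. Among the measured compounds shown here, no measured step speaks to this change, so no direction beyond the scatter is expected for a 1.1-fold higher number from compound 2 to compound 4 (0.04 log units; within the scatter). Compound 4 is estimated at 7000 nM, between 2500 nM and 20000 nM, and since compound 3 sits at the limit of > 10000 nM in this assay, at which 1 of the 3 values shown sits, and compound 1 at the limit of > 5000 nM in this assay, at which 1 of the 3 values shown sits, a limit rather than a number is quite possible.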

Compound 4, half-maximal cytotoxic concentration: > 5000 nM
Compound 4 was reported as a limit; the forecaster's own chance of this, stated with the estimate: 40%; the middle value does not contradict the limit.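

Within the data shown here, compound 4 is reported only as a limit, so no step from compound 2 to compound 4 can be read. The compounds shown leave open whether carbamoyl in place of methoxymethoxy on an aromatic carbon changes the number in this assay at all.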